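A few compounds are considered here, and "the series" means these few. Any claim that something is new, unique, unknown or untested is made for them only; others in the source may bear on it.

The three measured compounds share one core and differ in the group carried on an aromatic nitrogen. Compound 1 `N#CCn1c2ccc([N+](=O)[O-])cc2c(=O)n1Cc1ccccc1` carries a cyano group there. In an ADME assay on L929 cells (Mus musculus) for cytotoxicity, read by resazurin assay, with a stated time of 48 h (on this read-out lower numbers stand for higher toxicity in this test and higher numbers for lower toxicity in this test), compound 1 gives only a limit of the test, > 256000 nM. Compound 2 `CCOC(=O)CCCn1c2ccc([N+](=O)[O-])cc2c(=O)n1Cc1ccccc1` has 2-(ethoxycarbonyl)ethyl in place of cyano, and in this assay compound 2 gives 78100 nM, which is an at least 3.2-fold lower number from compound 1 to compound 2 (0.51 log units; beyond the scatter). Compound 3 `NC(=O)CCCn1c2ccc([N+](=O)[O-])cc2c(=O)n1Cc1ccccc1` has amino in place of ethoxy on the carbonyl carbon, and in this assay compound 3 again gives only a limit, > 256000 nM. That reading is an at least 3.2-fold higher number from compound 2 to compound 3 (0.51 log units; beyond the scatter), while a step that the two limits leave unreadable from compound 1 to compound 3. Compound 3 thus sits at the limit of > 256000 nM in this assay, at which 2 of the 3 values shown sit, the least toxic position any compound here has reached.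

Compound 4 `O=C(c1ccccc1)n1c2ccc([N+](=O)[O-])cc2c(=O)n1Cc1ccccc1` is not yet measured. It differs from compound 3 by benzoyl in place of 3-carbamoylpropyl on an aromatic nitrogen. Among the measured compounds shown here, no measured step swaps a chain for benzoyl, so the two modest steps above only show that this position can shift the number either way. Compound 4 is therefore expected to land near 120000 nM, within 40000 nM to 300000 nM, an estimated at least 2.1-fold lower number from compound 3 to compound 4 (0.32 log units; beyond the scatter).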

Compound 4, concentration lethal to 50% of the cells: 146000 nM
Compound 4: middle estimate off by 1.2-fold (0.09 log units), on the low side; low and high end bracket the measured number.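

This result brings the first aromatic ring onto this nitrogen, and benzoyl gives a readable number rather than a limit of the test. Compound 4 cannot be told apart from compound 2, which carries the ester chain, as the data show a 1.9-fold higher number from compound 2 to compound 4 (0.27 log units; within the scatter). Against the two compounds that sit at a limit, the readings are an at least 1.7-fold lower number from compound 3 to compound 4 (0.24 log units; that floor lies within the scatter) and an at least 1.7-fold lower number from compound 1 to compound 4 (0.24 log units; that floor lies within the scatter), so neither comparison yet shows a real difference.

From the compounds shown here alone, whether the carbonyl or the ring of benzoyl sets the number in this assay stays open, and an acetyl group or a phenyl group on this nitrogen would separate the two. Also open, going by these compounds, is how a carboxylic acid at the end of the chain would compare with the ester of compound 2 and the amide of compound 3.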